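A diethylamino group added to the hydrazone ring

The source may hold more compounds than are shown below. What is called first, only, known or untested is meant among the compounds shown, and "the series" means these compounds.

Two measured compounds share a core built around a hydrazone joined to an amide chain. Compound 1 has the structure `Cc1ccc(C(=O)NCC(=O)N/N=C/c2ccccc2OCc2ccccc2Cl)cc1` and compound 2 the structure `O=C(CNC(=O)c1ccc(F)cc1)N/N=C/c1ccccc1OCc1ccccc1Cl`. In a functional assay on HepG2 cells (Homo sapiens) for inhibition, read by MTT assay, with a stated time of 24 h (a higher number here means a weaker inhibitor, a lower number a stronger inhibitor), compound 1 gives 13400 nM, and compound 2 gives 24900 nM. Compound 1 thus has the lower of the two numbers, but the step of a 1.9-fold higher number from compound 1 to compound 2 (0.27 log units; within the scatter) does not separate the two beyond what repeated measurements of this kind usually show.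

Compound 3, with the structure `CCN(CC)c1ccc(/C=N/NC(=O)CNC(=O)c2ccc(C)cc2)c(OCc2ccccc2Cl)c1`, differs from compound 1 in one place: diethylamino in place of hydrogen on an aromatic carbon. Among the measured compounds shown here, no measured pair shows what adding a diethylamino group does here; the single known step concerns a change on the other end of the molecule and was itself small. There is therefore no basis for expecting a shift beyond the scatter in this assay in either direction, though the range around any guess must be wide. Compound 3 is estimated at 12000 nM, with a range from 3000 nM to 45000 nM. This estimate means the step of a 1.1-fold lower number from compound 1 to compound 3 (0.05 log units; within the scatter) is expected to stay inside the usual scatter.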

Compound 3, half-maximal inhibitory concentration: > 50000 nM
Compound 3 was reported as a limit; the forecaster's own chance of this, stated with the estimate: 15%; at least 4.1-fold (0.61 log units) between middle value and limit.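

Before this result, the only step on the shared core, a 1.9-fold higher number from compound 1 to compound 2 (0.27 log units; within the scatter), gave no sign that a single change could move the reading in a clear way. Among the compounds shown here, the aromatic carbon that lies meta to the (2-chlorobenzyl)oxy group is the first place where a change goes beyond the scatter, and it goes towards a weaker inhibitor. In this assay compound 3 gives > 50000 nM, which is a limit of the assay and not a number, so diethylamino in place of hydrogen gives an at least 3.7-fold higher number from compound 1 to compound 3 (0.57 log units; beyond the scatter), and only the lower end of this step can be read because the reading for compound 3 sits at that limit: the limit of > 50000 nM in this assay, at which 1 of the 3 values shown sits.

As far as these compounds go, with one group at this carbon, it stays open whether any group there weakens the compound or whether the effect belongs to diethylamino alone, and a methoxy group, a dimethylamino group or a plain primary amine in the same place would help to tell these apart. From the compounds shown here alone, it is also open whether the same loss would appear with the fluoro group of compound 2 at the other end of the molecule.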